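Dropping the Nitro Group: From Compound 2 to Compound 4

The source may hold more compounds than are shown below. What is called first, only, known or untested is meant among the compounds shown, and "the series" means these compounds.

Of the compounds shown here, three have so far been tested in a functional assay on the whole organism (strain Swiss albino) with Mus musculus as the target, in the maximal electroshock model, with a stated time of 4 h; on this read-out lower numbers stand for an effect already at smaller amounts and higher numbers for an effect only at larger amounts of compound. Compound 1 `C/C(=N\Cc1cccnc1)c1cccc(N)c1` gives 30 mg/kg, compound 2 `O=[N+]([O-])c1ccc(/C=N/Cc2cccnc2)cc1` gives 100 mg/kg, and compound 3 `C(=C/c1ccccc1)\C=N\Cc1cccnc1` gives 300 mg/kg. Compound 2 thus holds the second highest of the three numbers, standing between compound 1 and compound 3, and both gaps lie beyond the usual scatter of repeated measurements. Compound 4 `C(=N/Cc1cccnc1)\c1ccccc1` has not yet been measured in this assay. It differs from compound 2 in one place: hydrogen in place of nitro on an aromatic carbon. Among the measured compounds shown here, no measured pair shows this same change, so its effect can only be judged from the spread of the three known values. Compound 4 is expected to give about 100 mg/kg, within a range from 30 mg/kg to 300 mg/kg. This estimate means an expected step of no change at the digits printed from compound 2 to compound 4 (within the scatter), that is, no change beyond the scatter in either direction.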

Compound 4, minimum effective dose: 30 mg/kg
Compound 4: the middle estimate sits 3.3-fold (0.52 log units) above what was measured; measured number inside the range.
By their numbers in this assay, from the lowest: compounds 1 and 4 (each within the scatter of the next); then compound 2; then compound 3.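

Among the compounds shown here, replacing nitro with hydrogen on this aromatic carbon, para to a group of 9 heavy atoms, gives a 3.3-fold lower number from compound 2 to compound 4 (0.52 log units; beyond the scatter) and is the first single change that can be read here. The number falls on loss of the nitro group, so the effect in this test does not depend on nitro at this position. Nothing measured on the compounds explains this step.

On these data alone, whether a methoxy group or a chlorine atom on this carbon would give a lower or higher number remains open. Also open, as far as these compounds go, is whether the same change would give a similar step on another core.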